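This account rests on a few compounds, and the source may have more. Where it says the series, first, only, none or still open, it means among the compounds named here.

For the measured compounds named here, compound 1 `CC(C)c1ccc(NC(=O)C2CCN(C/C=C/c3ccccc3)CC2)cc1` is one of two compounds measured so far in a functional assay on MCF7 cells (Homo sapiens) for inhibition, read by MTT assay, with a stated time of 72 h; a higher number here means a weaker inhibitor, a lower number a stronger inhibitor. In this assay compound 1 gives 9100 nM, which is the highest of the two numbers, so it is the weaker of the pair. Its nearest neighbour is compound 2 `CCCCCc1ccc(NC(=O)C2CCN(C/C=C/c3ccccc3)CC2)cc1`, which in this assay gives 3740 nM. Going by the values given here, the only measured step, pentyl in place of isopropyl on an aromatic carbon, brings a 2.4-fold lower number from compound 1 to compound 2 (0.39 log units; beyond the scatter).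

The next compound, compound 3 `O=C(Nc1cccc(Br)c1)C1CCN(C/C=C/c2ccccc2)CC1`, departs from compound 1 in a different way: 3-bromophenyl in place of 4-isopropylphenyl on an amide-type nitrogen. The measured step from compound 1 to compound 2 altered only the alkyl group on that aromatic ring and left the ring itself in place, so it does not speak directly to swapping the whole 4-isopropylphenyl group for a 3-bromophenyl group. Among the compounds with values here, no measured step bears on this exchange. With no guide in either direction, the expected result is a number close to that of compound 1, with wide uncertainty. The step from compound 1 to compound 3 is therefore expected to be a 1.1-fold higher number from compound 1 to compound 3 (0.04 log units; within the scatter). Compound 3 is estimated to give 10000 nM in this assay, within a range from 3000 nM to 32000 nM.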

Compound 3, half-maximal inhibitory concentration: 11500 nM
Estimate against measurement, compound 3: 1.2-fold (0.06 log units) below, and the stated range covers the measured number.
By their numbers in this assay, from the lowest: compound 2; then compounds 1 and 3 (each within the scatter of the next).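

Swapping the whole 4-isopropylphenyl group on the amide-type nitrogen for 3-bromophenyl brings a 1.3-fold higher number from compound 1 to compound 3 (0.10 log units; within the scatter) in this assay, so this pair cannot be told apart, although the step is a much larger structural change than the alkyl swap measured earlier. The group that leaves has 9 heavy atoms and the group that enters has 7, and the bromine replaces an isopropyl group at a different place on the ring, yet neither difference leaves a readable mark on the number, which shows that at this position a change of this kind need not shift the result beyond the scatter. No measurement shown here gives a reason for this outcome, and the single step cannot separate the effect of changing the substituent from that of moving it.

The compounds shown leave open whether a ring carrying an amine or a carboxylic acid in place of the bromine would move the number beyond the scatter. They also leave open whether a chain longer than pentyl on the ring would give a lower number still.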